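The source may hold more compounds than are shown below. What is called first, only, known or untested is meant among the compounds shown, and "the series" means these compounds.

Working notes on the series. In an ADME assay on HepG2 cells (Homo sapiens) for cytotoxicity, read by CellTiter-Glo and ATP content, with a stated time of 72 h (a higher number here means that more compound is needed for the effect, a lower number that less compound is needed), compound 1 `CS(=O)(=O)c1ccc(C(=O)NCCCC(=O)N2Cc3ccccc3C2)cc1[N+](=O)[O-]` reaches only the assay limit, > 27000 nM. Compound 2 `CN1CCN(C(=O)CNC(=O)c2ccc(S(C)(=O)=O)c([N+](=O)[O-])c2)CC1` likewise gives a limit in this assay, > 27000 nM. Compound 3 `CC(C)N(C(=O)CCNC(=O)c1ccc(S(C)(=O)=O)c([N+](=O)[O-])c1)C(C)C` also returns a limit in this assay, > 27000 nM. Going by the values given here, compound 3 therefore stands at the limit of > 27000 nM in this assay, at which 3 of the 3 values shown sit, so its numbers give no ranking among the three and no measured step is available to lean on.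

Compound 4 `CC1CCN(C(=O)CCNC(=O)c2ccc(S(C)(=O)=O)c([N+](=O)[O-])c2)CC1` differs from compound 3 by 4-methylpiperidin-1-yl in place of diisopropylamino on a carbonyl carbon. In this assay, the step that the limit leaves unreadable from compound 3 to compound 4 is expected to be none beyond the scatter, because compound 3 sits at the limit of > 27000 nM in this assay, at which 3 of the 3 values shown sit, together with the other two. Compound 4 is expected at 40000 nM in this assay, with a range of 20000 nM to 100000 nM, most likely reported again as a limit.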

Compound 4, half-maximal effective concentration: > 27000 nM
Compound 4: no number, only a limit (the forecaster's own chance of this, stated with the estimate: 85%); the middle value is on the limit's open side.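

Compound 3 and compound 4 both give only a limit, so no step can be read between them: the limit of > 27000 nM in this assay, at which 4 of the 4 values shown sit.

The compounds shown leave open which structural change, if any, would give a number rather than a limit in this assay.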